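Changing the amide group of compound 1: an estimate

The source may hold more compounds than are shown below. What is called first, only, known or untested is meant among the compounds shown, and "the series" means these compounds.

Measured compounds:
compound 1, `CCCN(CC1CCOC1)C(=O)c1cc(OC)c2oc(NCc3cccc(Cl)c3)nc2c1`, with 12 nM
compound 2, `CCCc1cc(C(=O)N(CCC)CC2CCOC2)cc2nc(NCc3cccc(Cl)c3)oc12`, with 957 nM

Both were tested in an assay on isolated protein for inhibition of thyroid hormone receptor beta (Homo sapiens), read by fluorescence, with a stated time of 30 min; a lower number here means a stronger inhibitor, a higher number a weaker inhibitor. Compound 1 gives 12 nM, the lowest of the two numbers. Compound 2 gives 957 nM. Among the measured compounds shown here, the single measured step, an 80-fold higher number from compound 1 to compound 2 (1.90 log units; beyond the scatter), comes from replacing a methoxy with a propyl on an aromatic carbon of the shared core, so it shows that the number is very sensitive to changes at that aromatic position.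

Compound 3, `COc1cc(C(=O)N2CCC(C)(C)C2)cc2nc(NCc3cccc(Cl)c3)oc12`, keeps the methoxy and instead alters the amide: 3,3-dimethylpyrrolidin-1-yl in place of ((oxolan-3-yl)methyl)(propyl)amino on a carbonyl carbon. For the measured compounds named here, no measured step touches this part of the molecule, so the one step available gives no direct guide to the size or direction of the change. The data only show that the core with a methoxy can give a low number. The expectation is therefore a modest weakening, with a wide range in this assay, expressed as a 3.3-fold higher number from compound 1 to compound 3 (0.52 log units; beyond the scatter). Compound 3 is estimated at 40 nM, with a range from 8 nM to 200 nM.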

Compound 3, half-maximal inhibitory concentration: 40 nM
Beside the measured number, compound 3's estimate shows no gap at the digits printed, and the stated range covers the measured number.
By their numbers in this assay, from the lowest: compound 1; then compound 3; then compound 2.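

In this assay, the amide part of the molecule, which neither earlier compound varied, also moves the number: placing 3,3-dimethylpyrrolidin-1-yl on the carbonyl carbon in place of ((oxolan-3-yl)methyl)(propyl)amino gives a 3.3-fold higher number from compound 1 to compound 3 (0.52 log units; beyond the scatter), a modest step that is still beyond the scatter. The entering group has fewer heavy atoms than the one that leaves and 0 hydrogen-bond acceptors against 1, yet compound 3 still gives 40 nM, so this position accepts a clear change of group with only a modest loss. Nothing here gives a cause for the rise, and the ring, the propyl chain and the oxygen all change in this single step.

Left open is which of these features carries the step: an unsubstituted pyrrolidin-1-yl or a morpholin-4-yl on the same carbonyl carbon would begin to separate them. Also open, as far as these compounds go, is how a group such as ethoxy or hydroxyl would behave in place of the methoxy, and whether the amide and methoxy changes add up, as compound 2 and compound 3 differ in two places and cannot be compared directly.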